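Swapping the aryl group on the core of compound 2

The source may hold more compounds than are shown below. What is called first, only, known or untested is meant among the compounds shown, and "the series" means these compounds.

Compound 2 `N#CC1=C(N)N(c2ccc(S(N)(=O)=O)cc2)C2=C(CCCC2)C1c1ccccc1O` gives 100% in a functional assay on Ehrlich cells (Mus musculus) for cytotoxicity, read by trypan blue exclusion, with a stated time of 2 h, tested at 100 ug/mL (on this read-out higher numbers stand for a stronger effect at the one concentration tested and lower numbers for a weaker effect), the highest of three numbers, though compound 1 `Cc1ccc(C2C(C#N)=C(N)N(c3ccc(S(N)(=O)=O)cc3)C3=C2CCCC3)cc1` with 90% lies within the scatter of it, and only compound 3 `N#CC1=C(N)N(c2ccc(S(N)(=O)=O)cc2)C2=C(CCCC2)C1/C=C/c1ccccc1` with 70% lies clearly beneath it. Compound 4 `N#CC1=C(N)N(c2ccc(S(N)(=O)=O)cc2)C2=C(CCCC2)C1c1cccc([N+](=O)[O-])c1` differs from compound 2 in one place: 3-nitrophenyl in place of 2-hydroxyphenyl on a saturated ring carbon. Among the compounds with values here, two measured steps bear on this: a number 10 percentage points higher from compound 1 to compound 2 (within the scatter), an aryl-for-aryl swap, and a number 30 percentage points lower from compound 2 to compound 3 (beyond the scatter), where an alkenyl group replaced the aryl. As compound 4 keeps an aryl group, a small downward step at most is expected, a number 10 percentage points lower from compound 2 to compound 4 (within the scatter), within or close to the scatter. Compound 4 is therefore estimated at 90%, between 70% and 100%.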

Compound 4, a percentage reported as activity, at one concentration (the size of the read-out at that concentration, not a potency): 12%
Beside the measured number, compound 4's estimate is 78 percentage points above it; measured number below the stated range.
By their numbers in this assay, from the lowest: compound 4; then compound 3; then compounds 1 and 2 (each within the scatter of the next).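

Keeping an aryl group on this saturated ring carbon does not by itself keep the effect in this assay: 3-nitrophenyl brings a number 88 percentage points lower from compound 2 to compound 4 (beyond the scatter) and a number 78 percentage points lower from compound 1 to compound 4 (beyond the scatter) in the two aryl comparisons. It also falls short of the alkenyl group, with a number 58 percentage points lower from compound 3 to compound 4 (beyond the scatter) on that swap, so the identity of the aryl group can matter more here than the change from aryl to 2-phenylethenyl. Nothing available explains this drop. The compounds shown leave open whether it follows the nitro group itself or would persist with an amine or a carboxylic acid on the same phenyl ring.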